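Removing a Trifluoromethyl Group from the Amide-Linked Ring

The source may report more compounds than this note shows. Statements on the series, on what has been measured and on what is new or still open speak of the compounds shown alone.

Measured compounds, with their values in a functional assay on NCI-H322M cells (Homo sapiens) for inhibition, read by sulforhodamine B assay, with a stated time of 48 h; on this read-out higher numbers stand for weaker inhibition of growth and lower numbers for stronger inhibition of growth:

- compound 1, `COc1cc(-c2nn(-c3cccc(NC(=O)c4ccc(Cl)c(C(F)(F)F)c4)c3)cc2-c2ccncc2)ccc1Cl`, gives 12800 nM
- compound 2, `COc1cc(-c2nn(-c3cccc(NC(=O)c4cccc(C(F)(F)F)c4)c3)cc2-c2ccncc2)ccc1Cl`, gives 10800 nM
- compound 3, `O=C(Nc1cccc(-n2cc(-c3ccncc3)c(-c3ccc(Cl)c(O)c3)n2)c1)Nc1cc(C(F)(F)F)cc(C(F)(F)F)c1`, gives 1310 nM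

Among these three numbers, compound 2 stands second highest. Its nearest neighbour is compound 1, and the two are separated only by a change within the scatter: a 1.2-fold lower number from compound 1 to compound 2 (0.07 log units; within the scatter). Compound 3 is furthest away, with a clearly lower number, but it differs from compound 2 in several places at once, so its value says nothing about any single change.

Compound 4, `COc1cc(-c2nn(-c3cccc(NC(=O)c4ccccc4)c3)cc2-c2ccncc2)ccc1Cl`, has not yet been measured in this assay. It differs from compound 2 in one place: hydrogen in place of trifluoromethyl on an aromatic carbon. For the measured compounds named here, the only measured step that bears on this is the one from compound 1 to compound 2, where a substituent on the same ring was replaced by hydrogen and the number hardly moved. Taking away the trifluoromethyl as well is a somewhat larger removal, and the ring is then left as benzoyl with no substituent, so a small drift toward a higher number is plausible, but nothing beyond the scatter is expected. The expected step is a 1.2-fold higher number from compound 2 to compound 4 (0.08 log units; within the scatter).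

Compound 4 is therefore estimated to give about 13000 nM in this assay, most likely between 6000 nM and 30000 nM.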

Compound 4, concentration for 50% growth inhibition: 4590 nM
Beside the measured number, compound 4's estimate is 2.8-fold (0.45 log units) above it, and the stated range ends above it.
By their numbers in this assay, from the lowest: compound 3; then compound 4; then compounds 2 and 1 (each within the scatter of the next).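

In this assay, for the compounds shown here, the trifluoromethyl group on the amide-linked ring is the first change here to move the number beyond the scatter: the step is a 2.4-fold lower number from compound 2 to compound 4 (0.37 log units; beyond the scatter), a modest gain in growth inhibition, whereas the earlier removal of chloro was only a 1.2-fold lower number from compound 1 to compound 2 (0.07 log units; within the scatter) and stayed within the scatter. Removing both substituents together gives a 2.8-fold lower number from compound 1 to compound 4 (0.45 log units; beyond the scatter), so among these three closely related compounds, the plain benzoyl group inhibits growth more strongly than either substituted ring, and this position needs neither group to retain activity. Nothing available here explains why the unsubstituted ring gives the lower number.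

From the compounds shown here alone, it remains open whether a methyl, an amine or a carboxylic acid on this ring would keep the number near that of compound 4 or shift it in either direction. Compound 3 also gives a low number, but it differs from compound 4 in several places at once, so the contribution of any single feature of compound 3, such as its urea link, remains unresolved.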